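Removing the vinyl group from a potent antiproliferative compound

The source may hold more compounds than are shown below. What is called first, only, known or untested is meant among the compounds shown, and "the series" means these compounds.

Compound 1 `C=C[C@@H]1C[C@@H](Cc2ccc(OC)c(O)c2)[C@H]2C(=O)C=CC(=C)[C@H]21`: 0.74 nM
Compound 2 `C=C1C=CC(=O)[C@@H]2[C@H](Cc3cc(OC)c(OC)c(OC)c3)CC[C@H]12`: > 1000 nM

For the measured compounds named here, in a functional assay on HCT-116 cells (Homo sapiens) for antiproliferative activity, with a stated time of 72 h (a higher number here means a weaker inhibitor, a lower number a stronger inhibitor), compound 1 gives 0.74 nM, the only true number available so far. For compound 2 the entry > 1000 nM is a limit of the assay and not a number.

The next compound to be tested is compound 3 `C=C1C=CC(=O)[C@@H]2[C@H](Cc3ccc(OC)c(O)c3)CC[C@H]12`. It differs from compound 1 in one place only, with hydrogen in place of vinyl on a saturated ring carbon. That carbon belongs to a five-membered non-aromatic ring of carbon only. Going by the values given here, no measured pair isolates this change, so its size can only be judged. In this assay a weakening beyond the usual scatter is expected, though its size is uncertain. The estimated change is a 41-fold higher number from compound 1 to compound 3 (1.61 log units; beyond the scatter). Compound 3 is expected at 30 nM, with an estimated range of 3 nM to 400 nM.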

Compound 3, half-maximal inhibitory concentration: 3.01 nM
For compound 3 the middle estimate is 10-fold (1.00 log units) above the measured one, and the stated range covers the measured number.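

For the compounds shown here, removing the vinyl group in this assay gives a 4.1-fold higher number from compound 1 to compound 3 (0.61 log units; beyond the scatter) and so shows that this saturated ring carbon of the five-membered ring does affect potency, which the earlier compounds could not show. The step is modest, however: the vinyl group adds to potency but is not required for it, since compound 3 still reaches 3.01 nM with only hydrogen at that carbon. Nothing available here bears on the reason for this step.

On these data alone, whether a methyl or ethyl group on this carbon would match the vinyl group of compound 1 remains open, and so does whether an amine or a hydroxymethyl group would be tolerated there. Whether the step holds in cell lines other than this one is also unresolved.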